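A few compounds are considered here, and "the series" means these few. Any claim that something is new, unique, unknown or untested is made for them only; others in the source may bear on it.

Compound 1 `CN(C)c1ccc(C=C2C(=O)N(c3ccc(Cl)cc3)N(c3ccc(Cl)cc3)C2=O)cc1` was tested in a functional assay on MCF7 cells (Homo sapiens) for cytotoxicity, read by MTT assay, with a stated time of 72 h (a higher number here means a weaker inhibitor, a lower number a stronger inhibitor), where compound 1 gives only a limit of the assay, > 128000 nM. Compound 2 `COc1ccc(C=C2C(=O)N(c3ccc(Cl)cc3)N(c3ccc(Cl)cc3)C2=O)cc1OC` likewise gives only a limit in this assay, > 128000 nM. Among the compounds with values here, the one measured step, a step that the two limits leave unreadable from compound 1 to compound 2, therefore cannot be read, and all that the numbers offer is the limit of > 128000 nM in this assay, at which 2 of the 2 values shown sit. Compound 3 `O=C1C(=Cc2c[nH]c3ccccc23)C(=O)N(c2ccc(Cl)cc2)N1c1ccc(Cl)cc1` differs from compound 1 by 1H-indol-3-yl in place of 4-(dimethylamino)phenyl on a double-bonded chain carbon bound to a double-bonded ring carbon. Within the data shown here, no measured step bears on this change beyond the two limits, so no movement beyond the scatter is expected. Compound 3 is expected near the same limit, about 150000 nM with a range from 40000 nM to 500000 nM, the estimated step being a step that the limit leaves unreadable from compound 1 to compound 3.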

Compound 3, half-maximal inhibitory concentration: 34200 nM
For compound 3 the middle estimate is 4.4-fold (0.64 log units) above the measured one; the whole stated range lies above it.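

Within the data shown here, with 1H-indol-3-yl on the double-bonded chain carbon bound to a double-bonded ring carbon, this assay gives the only readable value among the three compounds, with an at least 3.7-fold lower number from compound 1 to compound 3 (0.57 log units; beyond the scatter) and with an at least 3.7-fold lower number from compound 2 to compound 3 (0.57 log units; beyond the scatter). Each step is only a minimum, since the other two compounds remain at a limit of the assay: the limit of > 128000 nM in this assay, at which 2 of the 3 values shown sit. Going by these compounds, this change can therefore move the number, though its full size stays unknown.

On these data alone, it remains open whether a 1-methyl-1H-indol-3-yl group would keep this lower number. The same question stands for a 4-hydroxyphenyl group at this place.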